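Swapping the sulfonyl aryl: from compound 3 to compound 4

The source may hold more compounds than are shown below. What is called first, only, known or untested is meant among the compounds shown, and "the series" means these compounds.

Compound 1 `COc1cccc(-c2c(S(=O)(=O)c3cccc(C#N)c3)cnc3cc(F)ccc23)c1`: in an ADME assay on microsomes from liver (Homo sapiens) for metabolic stability, tested at 2.5 uM (a lower number here means slower removal, a higher number faster removal of the compound), compound 1 gives 1.83 mL/min.
Compound 2 `N#Cc1cccc(S(=O)(=O)c2cnc3cc(F)ccc3c2-c2cccc(F)c2)c1`: compound 2 gives 0.78 mL/min.
Compound 3 `O=S(=O)(c1cc(F)cc(F)c1)c1cnc2cc(F)ccc2c1-c1cccc(Cl)c1`: compound 3 gives 0.22 mL/min.

Compound 3 stands lowest of the three numbers, beyond the scatter from both others. Compound 4 `N#Cc1cccc(S(=O)(=O)c2cnc3cc(F)ccc3c2-c2cccc(Cl)c2)c1` is compound 3 with one change: 3-cyanophenyl in place of 3,5-difluorophenyl on a sulfonyl sulfur. Within the data shown here, no measured step touches this part of the molecule; the one step known, a 2.3-fold lower number from compound 1 to compound 2 (0.37 log units; beyond the scatter), concerns the other aryl ring and so bears on it only loosely. Compound 2, which carries the same 3-cyanophenyl on its sulfonyl sulfur, shows a value above that of compound 3, so compound 4 is expected to move up, a step of a 2.3-fold higher number from compound 3 to compound 4 (0.36 log units; beyond the scatter). Compound 4 is estimated at 0.5 mL/min, within 0.2 mL/min to 1.2 mL/min.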

Compound 4, intrinsic clearance in a liver preparation (reported as CLH), per the amount of preparation that the assay uses: 0.99 mL/min
Compound 4: middle estimate off by 2.0-fold (0.30 log units), on the low side; the measured number falls inside the stated range.
By their numbers in this assay, from the lowest: compound 3; then compounds 2, 4 and 1 (each within the scatter of the next, the first and the last beyond it).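

In this assay, among these compounds, the group on the sulfonyl sulfur proves to matter: 3-cyanophenyl in place of 3,5-difluorophenyl gives a 4.5-fold higher number from compound 3 to compound 4 (0.65 log units; beyond the scatter), the first measured step at this position. With 3-cyanophenyl on the sulfonyl sulfur, chloro in place of fluoro gives a 1.3-fold higher number from compound 2 to compound 4 (0.10 log units; within the scatter) and chloro in place of methoxy gives a 1.8-fold lower number from compound 1 to compound 4 (0.27 log units; within the scatter), so chloro stands apart from neither. Nothing at hand explains the step at the sulfonyl sulfur. The compounds leave open whether that step holds with fluoro or methoxy in place of chloro, and how an amine on that aromatic ring would read.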